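Bromine on an Indole and Cytotoxicity in XF498 Cells

A few compounds are considered here, and "the series" means these few. Any claim that something is new, unique, unknown or untested is made for them only; others in the source may bear on it.

Measured so far in an ADME assay on XF498 cells (Homo sapiens) for cytotoxicity; a higher number here means that more compound is needed for the effect, a lower number that less compound is needed:
compound 1 `O=C1NC[C@@H](c2c[nH]c3cc(Br)ccc23)N=C1c1c[nH]c2ccccc12` gives 8.3 ug/mL.
compound 2 `O=C1NC[C@@H](c2c[nH]c3ccccc23)N=C1c1c[nH]c2ccccc12` gives 24.1 ug/mL.
compound 3 `O=C1NC[C@@H](c2c[nH]c3ccccc23)N[C@H]1c1c[nH]c2ccccc12` gives > 10 ug/mL, which is a limit of this assay and not a number.

Compound 1 and compound 2 share one core and differ only by bromo in place of hydrogen on an aromatic carbon; that change made a 2.9-fold lower number from compound 2 to compound 1 (0.46 log units; beyond the scatter). The difference between the core of compound 3 and the core of compound 2 is not broken down here.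

Compound 4 `O=C1NC[C@@H](c2c[nH]c3ccccc23)N[C@H]1c1c[nH]c2cc(Br)ccc12` has not been measured. It differs from compound 3 by bromo in place of hydrogen on an aromatic carbon, the same change as between compound 2 and compound 1. From compound 3 to compound 4 a step of a number no higher from compound 3 to compound 4 (the limit leaves the size open) is expected, resting on the earlier step of a 2.9-fold lower number from compound 2 to compound 1 (0.46 log units; beyond the scatter), though the starting point is uncertain because compound 3 sits at the limit of > 10 ug/mL in this assay, at which 1 of the 3 values shown sits. Compound 4 is therefore estimated to give about 10 ug/mL.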

Compound 4, concentration for half-maximal effect: 9.74 ug/mL
For compound 4 the middle estimate is 1.0-fold (0.01 log units) above the measured one; measured number inside the range.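

In this assay, bromo in place of hydrogen on an aromatic carbon gives an at least 1.0-fold lower number from compound 3 to compound 4 (0.01 log units; that floor lies within the scatter). On these data alone, compound 3 gives > 10 ug/mL, which is a limit of the assay and not a number, so the true size of this step remains unknown. The result is compatible with the change carrying over from one core to the other, but it does not prove that it does, and it cannot show that the size of the step carries over: the same change on two cores in this assay, a 2.9-fold lower number (0.46 log units; beyond the scatter) from compound 2 to compound 1 and an at least 1.0-fold lower number (0.01 log units; that floor lies within the scatter) from compound 3 to compound 4; the limit leaves it open whether they differ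

Among the compounds shown, bromo is the only group other than hydrogen at this place on either core. As far as these compounds go, how chloro, methyl or an amine would behave there remains open.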